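A Mirror-Image Change at One Saturated Ring Carbon

A few compounds are considered here, and "the series" means these few. Any claim that something is new, unique, unknown or untested is made for them only; others in the source may bear on it.

Of the compounds shown here, three have been measured in an assay on isolated protein for inhibition of DNA topoisomerase 1 (Homo sapiens), with a stated time of 15 min; a higher number here means a weaker inhibitor, a lower number a stronger inhibitor. Compound 1 `CNC(=O)c1cn(Cc2ccc(-c3ccccc3)cc2)c2c(OC)c(N3CC[C@@H](CN)C3)c(F)cc2c1=O` gives 82100 nM. Compound 2 `O=C(O)c1cn(Cc2ccc(-c3ccccc3)cc2)c2cc(NC[C@@H]3CCNC3)c(F)cc2c1=O` gives 104000 nM, and compound 3 `O=C(O)c1cn(Cc2ccc(-n3cccn3)cc2)c2cc(NC[C@@H]3CCNC3)c(F)cc2c1=O` gives 200000 nM. Among these three numbers compound 2 stands second highest; its nearest neighbour is compound 1, and its furthest is compound 3, to which it is separated by a 1.9-fold higher number from compound 2 to compound 3 (0.28 log units; within the scatter), so all three sit within the scatter of one another.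

The step under consideration leads from compound 2 to compound 4 `O=C(O)c1cn(Cc2ccc(-c3ccccc3)cc2)c2cc(NC[C@H]3CCNC3)c(F)cc2c1=O`. The change is the two compounds have the same atoms and bonds and differ only in configuration as drawn: 1 of 1 stereo elements differ; a stereocentre at a saturated ring carbon is drawn R in compound 2 and S in compound 4. Nothing leaves and nothing enters; the two compounds share every atom and bond.

Among the compounds with values here, the only measured step, a 1.9-fold higher number from compound 2 to compound 3 (0.28 log units; within the scatter), concerns an aromatic substituent and does not touch the saturated ring carbon, so no measured comparison bears directly on this change. Of compound 4 in this assay the expectation is therefore a number close to that of compound 2, with no step beyond the scatter; the expected step is a 1.1-fold higher number from compound 2 to compound 4 (0.02 log units; within the scatter). Compound 4 is estimated at 110000 nM, with a range from 40000 nM to 300000 nM.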

Compound 4, half-maximal inhibitory concentration: 100000 nM
Compound 4: the middle estimate sits 1.1-fold (0.04 log units) above what was measured, within the range that was stated.
By their numbers in this assay, from the lowest: compounds 1, 4, 2 and 3 (each within the scatter of the next, the first and the last beyond it).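

In this assay, turning the drawn stereocentre at the saturated ring carbon from R to S gives a 1.0-fold lower number from compound 2 to compound 4 (0.02 log units; within the scatter), so this read-out does not separate the two configurations in this pair. Within the data shown here, the earlier step concerned only an aromatic substituent and left this ring carbon untouched, which makes this the first measured comparison that bears on the position itself. The comparison isolates configuration at this one carbon, because nothing else separates the pair: the fact that compounds 2 and 4 differ only in the configuration as drawn

The compounds shown leave open whether configuration at this carbon is equally without consequence in another setting, such as the 1H-pyrazol-1-yl series of compound 3 or a compound with a clearly lower number in this assay, since all of the pairs here lie within the scatter. They also leave open what a methyl or hydroxyl group on the saturated ring, or a longer chain joining that ring to the shared core, would do to the number, and whether configuration would matter once such a group is present.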